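Series notes: from compound 2 to compound 4

This account rests on a few compounds, and the source may have more. Where it says the series, first, only, none or still open, it means among the compounds named here.

Three members of the series have been measured in a functional assay on the whole organism (COLO 205 cells) for inhibition, with Mus musculus as the target, read by polymerase chain reaction, in a xenograft, with a stated time of 8 h, at a dose of 40 mg/kg by the oral route; a lower number here means less inhibition, a higher number more inhibition at the dose given (going by the name of the read-out). Compound 1 `Cc1ccc(-c2cnc(C)n2C)cc1NC(=O)c1ccc(OCc2ccccn2)cc1` gives 12%. Compound 3 `Cc1cc(F)c(-c2ncc[nH]2)cc1NC(=O)c1ccc(OCc2ccccn2)cc1` gives 73%. Compound 2 `Cc1cc(C)c(-c2cn(C)cn2)cc1NC(=O)c1ccc(OCc2ccccn2)cc1` gives 87%, the highest of the three: compound 3 stands lower by a margin beyond the scatter, and compound 1 lies far lower still. No two of these compounds differ in a single place, so no isolated step can be read from the measured set; the three values show only that the substituents on the shared core move the read-out over a wide span.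

Compound 4 `Cc1cc(C)c(-c2ccc(N)nn2)cc1NC(=O)c1ccc(OCc2ccccn2)cc1` is the next candidate. Relative to compound 2 the change is 6-aminopyridazin-3-yl in place of 1-methyl-1H-imidazol-4-yl on an aromatic carbon. The entering group carries a hydrogen-bond donor where the leaving group had none, and one acceptor more.

Going by the values given here, with no measured pair covering a change of this kind, the expectation rests on compound 2 alone, and the exchange is large enough that a loss beyond the scatter is expected, with wide uncertainty. The expected step is a number 32 percentage points lower from compound 2 to compound 4 (beyond the scatter). For compound 4 the expected read-out in this assay is 55%, estimated to fall between 15% and 85%.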

Compound 4, a percentage reported as inhibition, in the whole organism at one dose (the size of the read-out at that dose, not a potency): 80%
Beside the measured number, compound 4's estimate is 25 percentage points below it; low and high end bracket the measured number.
By their numbers in this assay, from the lowest: compound 1; then compounds 3, 4 and 2 (each within the scatter of the next, the first and the last beyond it).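

Going by these compounds alone, the step of a number 7 percentage points lower from compound 2 to compound 4 (within the scatter) in this assay is the first single-place comparison, and it concerns the aromatic carbon ortho to a methyl group and para to a methyl group. At this place, 6-aminopyridazin-3-yl can stand in for 1-methyl-1H-imidazol-4-yl, a six-membered aromatic ring replacing a five-membered one and a hydrogen-bond donor entering where the leaving group had none, with no change in the read-out that can be told from the scatter at this single dose and time. Nothing in the data in hand bears on why the read-out holds across this exchange.

Within the data shown here, compound 1 and compound 3 each differ from the others in more than one place, and no step involving either can be read. From the compounds shown here alone, it remains open whether the amino group of 6-aminopyridazin-3-yl contributes to the read-out at all, a question that a methylamino group or a hydroxyl group at that spot on the ring, or a bare ring without the amine, would address.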